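Aryl swap on the ethenyl ester of compound 3

The source may hold more compounds than are shown below. What is called first, only, known or untested is meant among the compounds shown, and "the series" means these compounds.

In an ADME assay on HepG2 2.2.15 cells (Homo sapiens) for cytotoxicity (on this read-out higher numbers stand for lower toxicity in this test and lower numbers for higher toxicity in this test), compound 1 (`O=C(OCCc1c(-c2ccccc2Cl)c2cc(Cl)ccc2[nH]c1=O)c1ccccc1`) gives 43000 nM and compound 2 (`O=C(OCCc1c(-c2ccccc2Cl)c2cc(Cl)ccc2[nH]c1=O)c1cccnc1`) gives 170000 nM. Compound 3 (`O=C(/C=C/c1cccc(F)c1)OCCc1c(-c2ccccc2Cl)c2cc(Cl)ccc2[nH]c1=O`) gives only a limit, > 1600000 nM.

Compound 4 (`COc1ccc(/C=C/C(=O)OCCc2c(-c3ccccc3Cl)c3cc(Cl)ccc3[nH]c2=O)cc1`) carries 4-methoxyphenyl in place of 3-fluorophenyl on a double-bonded chain carbon bound to a double-bonded chain carbon.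

The measured steps all change the group on a carbonyl carbon. The step of a 4.0-fold higher number from compound 1 to compound 2 (0.60 log units; beyond the scatter) is modest, an at least 37-fold higher number from compound 1 to compound 3 (1.57 log units; beyond the scatter) is large, and an at least 9.4-fold higher number from compound 2 to compound 3 (0.97 log units; beyond the scatter) is at least modest. None of them changes the aryl group on the ethenyl chain, so they bear on this change only indirectly. Compound 4 keeps the ethenyl chain that accompanies the large step of an at least 37-fold higher number from compound 1 to compound 3 (1.57 log units; beyond the scatter), so a value nearer compound 3 than compound 1 is expected, with a modest move towards lower numbers or none that can be resolved.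

The expected step is an at least 2.6-fold lower number from compound 3 to compound 4 (0.42 log units; beyond the scatter).

Compound 4 is estimated at 600000 nM, with an expected range of 100000 nM to 2500000 nM.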

Compound 4, half-maximal cytotoxic concentration: > 1200000 nM
Compound 4 was reported as a limit; the forecaster's own chance of this, stated with the estimate: 35%; middle value at least 2.0-fold (0.30 log units) from the limit.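

Compound 4 also ends in a limit of the assay in this assay, at > 1200000 nM. The step between compound 3 and compound 4 cannot be read, so the swap of 3-fluorophenyl for 4-methoxyphenyl has neither a size nor a direction here. What is new is that a second aryl ethenyl ester also stands clear of the pyridin-3-yl and phenyl esters, with an at least 7.0-fold higher number from compound 2 to compound 4 (0.84 log units; beyond the scatter) and an at least 27-fold higher number from compound 1 to compound 4 (1.44 log units; beyond the scatter), so the high numbers are not tied to 2-(3-fluorophenyl)ethenyl alone.

The compounds shown leave open how far beyond their limits compound 3 and compound 4 lie, and so whether the aryl group on the chain matters at all in this test. Also open, as far as these compounds go, is how an amine on that aryl group, or a saturated ethyl chain in place of the ethenyl, would read.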